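The source may hold more compounds than are shown below. What is called first, only, known or untested is meant among the compounds shown, and "the series" means these compounds.

Working notes on the series. In a functional assay on HCT-116 cells (Homo sapiens) for inhibition, read by sulforhodamine B assay, with a stated time of 48 h, tested at 50 uM (a lower number here means less inhibition of growth, a higher number more inhibition of growth at the concentration tested), compound 1 `COc1cc(/C=C/C(=O)/C=C/c2ccco2)ccc1OCc1cn(CCCOc2cc(=O)oc3ccccc23)nn1` gives 51%, the second highest of the three numbers. Compound 2 `COc1cc(/C=C/C(=O)/C=C/c2cccs2)ccc1OCc1cn(CCOc2cc(=O)oc3ccccc23)nn1` stands higher at 71%, and compound 3 `COc1cccc(/C=C/C(=O)/C=C/c2ccc(OCc3cn(CCCCCOc4cc(=O)oc5ccccc45)nn3)c(OC)c2)c1` stands lower at 36%; both gaps from compound 1 lie beyond the scatter. Going by the values given here, no two measured compounds differ in only one place, so this change has no direct precedent in the data.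

Compound 4 `COc1ccc(/C=C/C(=O)/C=C/c2ccc(OCc3cn(CCCOc4cc(=O)oc5ccccc45)nn3)c(OC)c2)cc1OC` departs from compound 1 by 3,4-dimethoxyphenyl in place of furan-2-yl on a double-bonded chain carbon bound to a double-bonded chain carbon. Among the compounds with values here, the only partial guide is compound 3, which also has a six-membered aromatic ring of carbon only in that place and gives 36%, but it differs from compound 1 elsewhere too, so the comparison is weak. A modest fall in this assay is therefore expected, one that may not clear the scatter. The expected size of the change is a number 9 percentage points lower from compound 1 to compound 4 (within the scatter). The estimated value for compound 4 is 42%, with an expected range from 25% to 60%.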

Compound 4, percent growth inhibition at one concentration: 67%
Compound 4: the middle estimate sits 25 percentage points below what was measured; the whole stated range lies below it.
By their numbers in this assay, from the lowest: compound 3; then compound 1; then compounds 4 and 2 (each within the scatter of the next).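

In this assay, going by these compounds alone, 3,4-dimethoxyphenyl in place of furan-2-yl on a double-bonded chain carbon bound to a double-bonded chain carbon gives a number 16 percentage points higher from compound 1 to compound 4 (beyond the scatter), the first change that can be read in one place. This position therefore accepts a six-membered aromatic ring of carbon only, with 10 heavy atoms against 5, and growth inhibition at the concentration tested does not fall. No measurement at hand bears on the reason for this step.

From the compounds shown here alone, whether the gain needs both methoxy groups remains open, since a plain phenyl or a phenyl carrying a dimethylamino group at this place would be needed to separate the ring from its substituents. Going by these compounds, the effect of the linking chain also stays open, since compound 2 and compound 3 each differ from compound 1 in more than one place.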